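The compounds below may be only part of what the source reports. "The series", "measured", "known", "first", "only" and "open" are said of these compounds alone.

Measured compounds in a functional assay on DU-145 cells (Homo sapiens) for cytotoxicity, read by MTT assay; a higher number here means a weaker inhibitor, a lower number a stronger inhibitor:
Compound 1 `CC(C)=CC[C@@H](OC(=O)c1ccco1)C1=CC(=O)c2c(O)ccc(O)c2C1=O` gives > 100000 nM, a limit of the assay, not a number.
Compound 2 `CC(C)=CC[C@@H](OCC(C)O)C1=CC(=O)c2c(O)ccc(O)c2C1=O` gives 16100 nM.
Compound 3 `CCC(CO[C@H](CC=C(C)C)C1=CC(=O)c2c(O)ccc(O)c2C1=O)OC(C)=O` gives 25400 nM.

Among the two numbers that are known, compound 3 stands highest, though its nearest neighbour is close: a 1.6-fold higher number from compound 2 to compound 3 (0.20 log units; within the scatter). The third value, for compound 1, is only a limit.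

Compound 4 `CC(C)=CC[C@@H](OC(=O)C1CCCOC1)C1=CC(=O)c2c(O)ccc(O)c2C1=O` differs from compound 3 in one place: (oxan-3-yl)carbonyl in place of 2-acetoxybutyl on an oxygen on a saturated carbon. The group that enters is a carbonyl group joined through an oxygen, as in compound 1, where a (furan-2-yl)carbonyl sits in the same place; the group that leaves is a chain of the same size without a carbonyl at the oxygen. The step that bears on this is the reverse of an at least 3.9-fold lower number from compound 1 to compound 3 (0.59 log units; beyond the scatter), together with an at least 6.2-fold lower number from compound 1 to compound 2 (0.79 log units; beyond the scatter), both showing that removing the carbonyl-bearing group lowered the number. Returning to such a group is therefore expected to raise the number, by roughly a 2.8-fold higher number from compound 3 to compound 4 (0.44 log units; beyond the scatter). Compound 4 is estimated at 70000 nM, between 20000 nM and 250000 nM.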

Compound 4, half-maximal inhibitory concentration: 29700 nM
Compound 4: middle estimate off by 2.4-fold (0.37 log units), on the high side; measured number inside the range.
By their numbers in this assay, from the lowest: compounds 2, 3 and 4 (each within the scatter of the next). At a limit, above all of these: compound 1.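

The carbonyl at this oxygen does not by itself go with the very high number of compound 1. In this assay, the (oxan-3-yl)carbonyl group reads level with both chains: a 1.2-fold higher number from compound 3 to compound 4 (0.07 log units; within the scatter), and a 1.8-fold higher number from compound 2 to compound 4 (0.27 log units; within the scatter). The difference instead appears with the ring on the carbonyl, where oxan-3-yl replaces furan-2-yl, giving an at least 3.3-fold lower number from compound 1 to compound 4 (0.52 log units; beyond the scatter), and compound 1 stands at a limit rather than a number, which leaves the full size of this step unknown: the limit of > 100000 nM in this assay, at which 1 of the 4 values shown sits.

Going by these compounds alone, with only two carbonyl groups at this oxygen, it remains open whether furan-2-yl alone sets compound 1 apart or whether other flat rings would read the same way. As far as these compounds go, how a phenyl ring on the carbonyl, or an amine or a carboxylic acid on the chain, would read in this assay also remains open.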